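This account rests on a few compounds, and the source may have more. Where it says the series, first, only, none or still open, it means among the compounds named here.

Of the compounds shown here, three built on one shared core have been tested in a functional assay on the whole organism (Tail, strain ICR) with Mus musculus as the target, in the tail flick test, with a stated time of 150 min, at a dose of 25 umol/kg by the oral route; on this read-out higher numbers stand for a stronger effect at the one dose given and lower numbers for a weaker effect. Compound 1 `O=C(CN(c1nc(Cl)nc2[nH]cnc12)C1CC1)N[C@@H](CO)C(=O)OCc1ccccc1` gives 27.9%, and compound 2 `O=C(CN(c1nc(Cl)nc2[nH]cnc12)C1CC1)NCC(=O)OCc1ccccc1` gives 18%. Compound 3 `N=C(N)NCCC[C@H](NC(=O)CN(c1nc(Cl)nc2[nH]cnc12)C1CC1)C(=O)O` gives 7.19%, the lowest of the three numbers, separated from compound 2 and from compound 1 by gaps beyond the scatter.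

Within the data shown here, the only measured step among them is a number 9.9 percentage points lower from compound 1 to compound 2 (within the scatter), a change at a different position from the one considered next.

Compound 4 `N=C(N)NCCC[C@H](NC(=O)CN(c1nc(Cl)nc2[nH]cnc12)C1CC1)C(=O)OCc1ccccc1` has not yet been measured and differs from compound 3 in one place: benzyl in place of hydrogen on an oxygen next to a carbonyl group. Among the measured compounds shown here, no measured step covers this change, and the one measured step is within the scatter. What the numbers do show is that both compounds carrying a benzyloxycarbonyl group, compound 1 and compound 2, stand above compound 3, which carries a carboxy group; but each of them also differs from compound 3 elsewhere, so this is only a hint, not a measured effect of the change.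

On that hint, compound 4 is expected to show a number 12.8 percentage points higher from compound 3 to compound 4 (beyond the scatter), moving toward the values of the other two compounds in this assay. The estimate for compound 4 is 20%, with a range from 8% to 35%. For the measured compounds named here, the range is wide: no measured step isolates this change.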

Compound 4, a percentage reported as activity, at one dose (the size of the read-out at that dose, not a potency): 6.12%
For compound 4 the middle estimate is 13.9 percentage points above the measured one, and the stated range ends above it.
By their numbers in this assay, from the lowest: compounds 4 and 3 (each within the scatter of the next); then compounds 2 and 1 (each within the scatter of the next).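

In this assay, benzyl on the oxygen next to the carbonyl group gives a number 1.1 percentage points lower from compound 3 to compound 4 (within the scatter), so turning carboxy into benzyloxycarbonyl makes no readable difference while the nitrogen-rich chain stays in place. This also removes the earlier hint, and the measured gaps now sit at the other position, the saturated chain carbon bound to an amide-type nitrogen and a carbonyl carbon, with the benzyl ester held constant: a group of 7 heavy atoms in place of a hydrogen atom gives a number 11.9 percentage points lower from compound 2 to compound 4 (beyond the scatter) and, on the same chain, a group of 6 heavy atoms in place of one oxygen atom gives a number 21.8 percentage points lower from compound 1 to compound 4 (beyond the scatter) in this comparison of side chains. Nothing measured here gives a reason for these steps.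

Still open, from the compounds shown here alone, is whether a carboxylic acid in place of the benzyl ester would also make no readable difference on the chains of compound 1 and compound 2, or whether a methyl ester would read like benzyloxycarbonyl. Going by these compounds, it is also open whether a simple amine at the end of a shorter chain would give the same drop as the longer nitrogen-bearing chain.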